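A few compounds are considered here, and "the series" means these few. Any claim that something is new, unique, unknown or untested is made for them only; others in the source may bear on it.

Within the data shown here, in a functional assay on A549 cells (Homo sapiens) for antiproliferative activity, read by MTT assay, with a stated time of 48 h (on this read-out higher numbers stand for weaker inhibition and lower numbers for stronger inhibition), compound 1 (`O=C(/C=C/c1ccc(Cl)cc1)Nc1cc(-c2ccccc2)[nH]n1`) gives 1390 nM and compound 2 (`O=C(/C=C/c1ccc([N+](=O)[O-])cc1)Nc1cc(-c2ccccc2)[nH]n1`) gives 970 nM so compound 2 stands within the usual scatter of its only measured neighbour. Compound 3 (`O=C(/C=C/c1ccc(Br)cc1)Nc1cc(-c2ccccc2)[nH]n1`) keeps the shared core and alters one group. The change is bromo in place of nitro on an aromatic carbon and amounts to bromo in place of nitro on an aromatic carbon, para to a large group. Among the measured compounds shown here, one measured step bears on this: the exchange of chloro for nitro at that same place gave a 1.4-fold lower number from compound 1 to compound 2 (0.16 log units; within the scatter) and bromo, like chloro, is a halogen. No measurement compares bromo with chloro directly, so this is only a guide. The expected change is small, with no shift beyond the scatter, and the estimate is a 1.3-fold higher number from compound 2 to compound 3 (0.13 log units; within the scatter) in this assay for this pair. Compound 3 is expected to give 1300 nM with an estimated range from 700 nM to 2400 nM around that value.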

Compound 3, half-maximal inhibitory concentration: 1460 nM
Estimate against measurement, compound 3: 1.1-fold (0.05 log units) below, and the stated range covers the measured number.
By their numbers in this assay, from the lowest: compounds 2, 1 and 3 (each within the scatter of the next).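

In this assay the nitro group, with 3 heavy atoms and 2 hydrogen-bond acceptors, gives way to bromo, with 1 heavy atom and no hydrogen-bond acceptors, and this gives a 1.5-fold higher number from compound 2 to compound 3 (0.18 log units; within the scatter) while the swap between the two halogens gives a 1.1-fold higher number from compound 1 to compound 3 (0.02 log units; within the scatter) and so adds the direct comparison that was missing before. All three groups at this place on the ring now lie within the scatter of one another, so these compounds do not separate chloro, nitro and bromo at this position. Nothing measured here explains why these numbers sit so close together.

Going by these compounds, it remains open whether an amine, a carboxylic acid or a longer chain at this place would stay within the scatter or move the number beyond it. On these data alone, the effect of changing the unsubstituted phenyl ring on the other side of the shared core also remains unknown.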